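Removing the chloro group: what does the bare ring do?

A few compounds are considered here, and "the series" means these few. Any claim that something is new, unique, unknown or untested is made for them only; others in the source may bear on it.

Measured compounds:
compound 1, `c1ccc(COc2ccc(C3CC(c4ccc5c(c4)OCCO5)=NN3c3ccccc3)cc2)cc1` — 1130 nM
compound 2, `Clc1ccc(C2CC(c3ccc4c(c3)OCCO4)=NN2c2ccccc2)cc1` — 38600 nM

In a functional assay on WM 266-4 cells (Homo sapiens) for antiproliferative activity, read by MTT assay, with a stated time of 24 h (on this read-out higher numbers stand for weaker inhibition of growth and lower numbers for stronger inhibition of growth), compound 2 gives the highest number of the two measured compounds; its nearest neighbour is compound 1, from which it differs by a 34-fold higher number from compound 1 to compound 2 (1.53 log units; beyond the scatter). Compound 3, `c1ccc(C2CC(c3ccc4c(c3)OCCO4)=NN2c2ccccc2)cc1`, follows from compound 2 by hydrogen in place of chloro on an aromatic carbon. Within the data shown here, no measured step touches this particular exchange; the only known step shows that the group at this position matters greatly, but it swapped a different group. A modest drift toward a higher number is therefore expected, a 1.4-fold higher number from compound 2 to compound 3 (0.15 log units; within the scatter), with wide uncertainty. Compound 3 is estimated at 55000 nM, between 15000 nM and 200000 nM.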

Compound 3, concentration for 50% growth inhibition: 22400 nM
Compound 3: middle estimate off by 2.5-fold (0.39 log units), on the high side, within the range that was stated.
By their numbers in this assay, from the lowest: compound 1; then compounds 3 and 2 (each within the scatter of the next).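

In this assay, replacing chloro with hydrogen gives no change that stands out from the scatter (a 1.7-fold lower number from compound 2 to compound 3 (0.24 log units; within the scatter)), so 4-chlorophenyl and phenyl cannot be told apart here. Compound 1, with benzyloxy at this position, stands well apart from the bare ring (a 20-fold higher number from compound 1 to compound 3 (1.30 log units; beyond the scatter)), so the large difference goes with benzyloxy, not with the presence or absence of chloro. No available evidence explains this. From the compounds shown here alone, it remains open whether a methoxy group, a hydroxyl group or a longer chain such as phenethyloxy would match benzyloxy here.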